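The source may hold more compounds than are shown below. What is called first, only, known or untested is meant among the compounds shown, and "the series" means these compounds.

Measured so far in an ADME assay on MDCK cells (Canis lupus familiaris) for cytotoxicity, with a stated time of 48 h; on this read-out lower numbers stand for higher toxicity in this test and higher numbers for lower toxicity in this test:
- compound 1, `C=C(C(=O)OC)[C@@H]1CC[C@H](C)[C@@H]2CC(=O)C(C)=C2C1`: 213 uM
- compound 2, `C=C(C(=O)OC)[C@@H]1CC[C@H](C)[C@H]2C(=C(C)C(=O)[C@H]2NC(=O)C(C)CCl)C1`: 735 uM
- compound 3, `C=C(C(=O)OC)[C@@H]1CC[C@H](C)[C@H]2C(=C(C)C(=O)[C@H]2NC(=O)CNC(=O)c2ccccc2)C1`: 488 uM

Compound 2 holds the highest number of the three. Against compound 3 the gap is a 1.5-fold lower number from compound 2 to compound 3 (0.18 log units; within the scatter), so the two cannot be ordered; against compound 1 the gap is a 3.5-fold higher number from compound 1 to compound 2 (0.54 log units; beyond the scatter).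

Compound 4, `C=C(C(=O)OC)[C@@H]1CC[C@H](C)[C@H]2C(=C(C)C(=O)[C@H]2NS(=O)(=O)c2ccc(F)cc2)C1`, is compound 2 with a group of 10 heavy atoms (6 carbon, 2 oxygen, 1 fluorine, 1 sulfur; one six-membered aromatic ring of carbon only) in place of a group of 6 heavy atoms (4 carbon, 1 oxygen, 1 chlorine; no ring), on an amine nitrogen.

For the measured compounds named here, two measured steps bear on this. The step of a 3.5-fold higher number from compound 1 to compound 2 (0.54 log units; beyond the scatter) shows that substitution on the saturated ring carbon raised the number. The step of a 1.5-fold lower number from compound 2 to compound 3 (0.18 log units; within the scatter) shows that replacing the group on the acyl side of that nitrogen left the number within the scatter. The new change again keeps the nitrogen substituted and exchanges what hangs on it, so no step beyond the scatter is expected in this assay, with at most a slight drift downward, as seen for compound 3.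

For compound 4 a value of 600 uM is expected, in the range 300 uM to 1200 uM, which means an expected step of a 1.2-fold lower number from compound 2 to compound 4 (0.09 log units; within the scatter).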

Compound 4, half-maximal toxic concentration: 25.1 uM
Compound 4: middle estimate off by 24-fold (1.38 log units), on the high side; the whole stated range lies above it.
By their numbers in this assay, from the lowest: compound 4; then compound 1; then compounds 3 and 2 (each within the scatter of the next).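

In this assay, for the compounds shown here, the substituent on the amine nitrogen matters far more than the earlier compounds suggested: (4-fluorophenyl)sulfonyl in place of the acyl group gives a 29-fold lower number from compound 2 to compound 4 (1.47 log units; beyond the scatter). The earlier exchange on the acyl side, a 1.5-fold lower number from compound 2 to compound 3 (0.18 log units; within the scatter), stayed within the scatter, so tolerance of that change does not extend to this sulfonyl group. No available data speak to a cause.

Going by these compounds, it remains open whether the step follows the sulfonyl linkage or the fluorinated aromatic ring. A methylsulfonyl group and a 4-fluorobenzoyl group on the same nitrogen would separate the two.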